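The source may hold more compounds than are shown below. What is called first, only, known or untested is meant among the compounds shown, and "the series" means these compounds.

Measured in an ADME assay on BEAS-2B cells (Homo sapiens) for cytotoxicity, read by fluorescence, with a stated time of 48 h; a higher number here means that more compound is tolerated, a lower number that less compound is tolerated:
- compound 1 `O=C(Nc1ccccc1)c1cc2n(n1)CCCN(C(=O)c1ccco1)C2`: "not determined" (no result reported)
- compound 2 `O=C(Nc1ccccc1)c1cc2n(n1)CCCN(C(=O)c1occc1C(F)(F)F)C2`: 30000 nM
- compound 3 `CCc1ccoc1C(=O)N1CCCn2nc(C(=O)Nc3ccccc3)cc2C1`: 10000 nM

Going by the values given here, compound 3, at 10000 nM, holds the lower of the only two numbers, and compound 1 provides no number for comparison. The next compound is compound 4 `Cc1coc(C(=O)N2CCCn3nc(C(=O)Nc4ccccc4)cc3C2)c1C`, still to be measured in this assay. The change is 3,4-dimethylfuran-2-yl in place of 3-ethylfuran-2-yl on a carbonyl carbon. In words, 3,4-dimethylfuran-2-yl stands in place of 3-ethylfuran-2-yl on a carbonyl carbon, and the two compounds have the same atoms, joined differently.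

Among the compounds with values here, only one measured step bears on this change: a 3.0-fold lower number from compound 2 to compound 3 (0.48 log units; beyond the scatter). It is modest, and it swaps trifluoromethyl for ethyl, so it is only an indirect guide to an exchange between ethyl and two methyl groups. Within the data shown here, no measured step covers that exchange directly. With that single modest step as the guide, a smaller move is expected here, with no step beyond the scatter and no firm direction. The step expected is a 1.3-fold higher number from compound 3 to compound 4 (0.11 log units; within the scatter). For compound 4 the estimated value is 13000 nM, with an expected range of 5000 nM to 35000 nM.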

Compound 4, half-maximal cytotoxic concentration: 30000 nM
Compound 4: middle estimate off by 2.3-fold (0.36 log units), on the low side; the measured number falls inside the stated range.
By their numbers in this assay, from the lowest: compound 3; then compounds 2 and 4 (each within the scatter of the next).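

In this assay, 3,4-dimethylfuran-2-yl in place of 3-ethylfuran-2-yl on the carbonyl carbon gives a 3.0-fold higher number from compound 3 to compound 4 (0.48 log units; beyond the scatter), so the read-out at this position depends on how the same atoms are joined and not only on which atoms are present. The 3-(trifluoromethyl)furan-2-yl and 3,4-dimethylfuran-2-yl groups give no change at the digits printed from compound 2 to compound 4 (within the scatter), which leaves compound 3, with its 3-ethylfuran-2-yl group, as the only one of the three measured compounds set apart from the others, and that lowest number rests on this single compound. Nothing shown explains why the ethyl compound differs from the other two.

Steps involving compound 1 cannot be read, since compound 1 gives "not determined" (no result reported), so the effect of any furan substituent relative to the plain furan-2-yl group remains unknown. As far as these compounds go, it also remains open whether a longer chain such as propyl, or an amine or a carboxylic acid on the furan, would read with compound 3 or with compounds 2 and 4, and so whether the lower number of compound 3 is specific to ethyl.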